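Chloro substitution on a fused core and cell growth inhibition

The source may hold more compounds than are shown below. What is called first, only, known or untested is meant among the compounds shown, and "the series" means these compounds.

The series rests on a shared core carrying a chloromethylbenzyl group. Compound 1 `ClCc1ccccc1Cn1cnc2c(Cl)nc(Cl)nc21` was examined in a functional assay on HOP-92 cells (Homo sapiens) for cytotoxicity, read by sulforhodamine B assay, with a stated time of 48 h (a higher number here means a weaker inhibitor of growth, a lower number a stronger inhibitor of growth), and gave 350 nM. Compound 2 `ClCc1cccc(Cn2cnc3ncnc(Cl)c32)c1` stands at "not determined" (no result reported) in this assay, so nothing can be said of it. Compound 3 `ClCc1ccccc1Cn1cnc2ncnc(Cl)c21` gave 4360 nM in this assay, the highest of the two numbers available; compound 1 gives a number lower by more than the usual scatter, but it differs from compound 3 in more than one place, so the two values are only compared, not traced to a single change.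

Compound 4 `ClCc1ccccc1Cn1cnc2nc(Cl)nc(Cl)c21` is the compound still to be measured. It differs from compound 3 by chloro in place of hydrogen on an aromatic carbon, so the core of compound 4 now carries two chloro groups, as does compound 1. Going by the values given here, no single-change step between measured compounds exists in this assay, so the expectation leans on compound 1 and compound 3 alone. The author expects compound 4 to fall toward the lower number, an estimated step from compound 3 to compound 4 of a 2.9-fold lower number from compound 3 to compound 4 (0.46 log units; beyond the scatter). Compound 4 is estimated at 1500 nM, with a range from 400 nM to 5500 nM.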

Compound 4, concentration for 50% growth inhibition: 1140 nM
Compound 4: the middle estimate sits 1.3-fold (0.12 log units) above what was measured; the measured number falls inside the stated range.
By their numbers in this assay, from the lowest: compound 1; then compound 4; then compound 3.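

In this assay, the change of hydrogen to chloro on an aromatic carbon, between two ring nitrogen atoms, gives a 3.8-fold lower number from compound 3 to compound 4 (0.58 log units; beyond the scatter), the first difference in this series that can be traced to a single change. Until now the two numbers available could only be set side by side, whereas this pair ties stronger growth inhibition directly to a second chloro group on the core, at this position and para to a fused ring, although the step is modest and rests on one pair of compounds. Nothing among the data shown explains why the added chloro group has this effect.

The compounds shown leave open whether the gain belongs to chloro itself or would also appear with another group at this position, such as an amine, a methoxy group or bromo. Going by these compounds alone, they also give no single-change step for the chloromethylbenzyl group or for the other chloro group on the core, so the contribution of each to growth inhibition remains unknown.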